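The source may hold more compounds than are shown below. What is called first, only, known or untested is meant among the compounds shown, and "the series" means these compounds.

Compound 3 `Cc1ncc([N+](=O)[O-])n1CC(O)CN1CCN(c2cccc(Cl)c2Cl)CC1` gives > 5000000 nM in a toxicity assay on HeLa cells (Homo sapiens) for cytotoxicity, read by MTT assay, with a stated time of 24 h (a higher number here means a weaker inhibitor, a lower number a stronger inhibitor), and that figure is a limit of the assay rather than a number. Compound 1 `Cc1ncc([N+](=O)[O-])n1CC(O)CN1CCN(c2ccccc2)CC1` likewise gives only a limit, > 5000000 nM. Compound 2 `Cc1ncc([N+](=O)[O-])n1CC(O)CN1CCN(c2cccc(Cl)c2)CC1` gives a real value, 1440000 nM. The steps run an at least 3.4-fold lower number from compound 1 to compound 2 (0.54 log units; beyond the scatter) and an at least 3.4-fold higher number from compound 2 to compound 3 (0.54 log units; beyond the scatter), while a step that the two limits leave unreadable from compound 1 to compound 3; two of the three values sit at the limit of > 5000000 nM in this assay, at which 2 of the 3 values shown sit. Compound 4 `Cc1ncc([N+](=O)[O-])n1CC(O)CN1CCN(c2ccco2)CC1` differs from compound 3 by furan-2-yl in place of 2,3-dichlorophenyl on an amine nitrogen in a ring. Among the measured compounds shown here, no measured step touches a furan-2-yl group, so the expectation rests only on compound 3 and compound 1 both sitting at the limit in this assay. He therefore expects a number no higher from compound 3 to compound 4 (the limit leaves the size open), with compound 4 estimated at 5000000 nM, between 1000000 nM and 10000000 nM.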

Compound 4, half-maximal inhibitory concentration: 3520000 nM
The estimate for compound 4 lay 1.4-fold (0.15 log units) above the measured number; measured number inside the range.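

In this assay, compound 4 shows that a readable value at this position does not depend on a chloro group, since furan-2-yl carries none. Set against 3-chlorophenyl, the change gives a 2.4-fold higher number from compound 2 to compound 4 (0.39 log units; beyond the scatter). The other two steps, an at least 1.4-fold lower number from compound 3 to compound 4 (0.15 log units; that floor lies within the scatter) and an at least 1.4-fold lower number from compound 1 to compound 4 (0.15 log units; that floor lies within the scatter), are only floors, because their starting compounds stand at a limit: the limit of > 5000000 nM in this assay, at which 2 of the 4 values shown sit.

On these data alone, whether a thiophen-2-yl or pyridin-2-yl group on the same nitrogen would also give a readable value stays open. So does how far compound 1 and compound 3 lie beyond that limit.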